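The compounds below may be only part of what the source reports. "The series", "measured", "known", "first", "only" and "open" are said of these compounds alone.

In an ADME assay on BHK cells (Mesocricetus auratus) for cytotoxicity, read by MTT assay (on this read-out lower numbers stand for higher toxicity in this test and higher numbers for lower toxicity in this test), the measured compounds stand as follows. Compound 1 `CC1CCCCC1N(CCCCCCN1C[C@H](O)[C@@H](O)[C@H](O)[C@H]1CO)C(=O)OC(C)(C)C` gives 230000 nM. Compound 2 `CC(=O)N(CCCCCCN1C[C@H](O)[C@@H](O)[C@H](O)[C@H]1CO)C1CCCCC1` reaches only the assay limit of > 500000 nM. Compound 3 `CC(C)(C)C(=O)N(CCCCCCN1C[C@H](O)[C@@H](O)[C@H](O)[C@H]1CO)c1ccc(F)cc1F` likewise reaches only the assay limit of > 500000 nM.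

Compound 3 therefore stands at the limit of > 500000 nM in this assay, at which 2 of the 3 values shown sit, and no number for it is known. Compound 4 `CC(C)(C)C(=O)N(CCCCCCN1C[C@H](O)[C@@H](O)[C@H](O)[C@H]1CO)C1CC1` differs from it by cyclopropyl in place of 2,4-difluorophenyl on an amide-type nitrogen. Among the compounds with values here, no measured pair shows this change, so no size of step can be read off. Compound 4 is expected to stay close to compound 3, with a step of a number no higher from compound 3 to compound 4 (the limit leaves the size open) that should lie within the scatter. Compound 4 is thus estimated at 500000 nM in this assay, between 250000 nM and 1000000 nM.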

Compound 4, half-maximal cytotoxic concentration: > 500000 nM
Compound 4 ended at the assay's limit; the forecaster's own chance of this, stated with the estimate: 65%; the middle value sits exactly at the limit.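

Within the data shown here, no step from compound 3 to compound 4 can be read in this assay: both compounds give only a limit of the assay, not a number. The compounds shown leave open whether cyclopropyl in place of 2,4-difluorophenyl changes the read-out at all.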